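Chloro Added to the Difluoromethyl Group of Compound 2

The source may hold more compounds than are shown below. What is called first, only, known or untested is meant among the compounds shown, and "the series" means these compounds.

Compound 2 `CC1CCN(c2nc(C(F)F)ccc2CNC(=O)C(C)c2ccc(NS(C)(=O)=O)c(F)c2)CC1` stands lowest of the two numbers in an assay on CHO cells for antagonist activity at transient receptor potential cation channel subfamily V member 1 (Homo sapiens), read by FLIPR (a lower number here means a stronger inhibitor, a higher number a weaker inhibitor), where compound 2 gives 1 nM. Its nearest neighbour, compound 1 `Cc1ccc(CNC(=O)C(C)c2ccc(NS(C)(=O)=O)c(F)c2)c(N2CCC(C)CC2)n1`, gives 72.1 nM in this assay. That gap is the step of a 72-fold lower number from compound 1 to compound 2 (1.86 log units; beyond the scatter), from difluoromethyl in place of methyl on an aromatic carbon. Compound 3 `CC1CCN(c2nc(C(F)(F)Cl)ccc2CNC(=O)C(C)c2ccc(NS(C)(=O)=O)c(F)c2)CC1` carries chloro in place of hydrogen on a saturated chain carbon bound to an aromatic carbon and two fluorine atoms. Among the measured compounds shown here, the one measured step concerns a different exchange on the same carbon, so it bears only loosely on this change. Compound 3 is therefore expected to stay near compound 2, a step of a 1.5-fold higher number from compound 2 to compound 3 (0.18 log units; within the scatter). The estimate for compound 3 is 1.5 nM, within 0.4 nM to 6 nM.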

Compound 3, inhibition constant: 0.3 nM
Estimate against measurement, compound 3: 5.0-fold (0.70 log units) above; the whole stated range lies above it.
By their numbers in this assay, from the lowest: compound 3; then compound 2; then compound 1.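

In this assay, the carbon already bearing two fluorine atoms still responds to a further exchange: chloro in place of hydrogen takes the number lower even from the low value of compound 2 (a 3.3-fold lower number from compound 2 to compound 3 (0.52 log units; beyond the scatter)). Measured from the methyl group, the full exchange to chloro(difluoro)methyl is large (a 240-fold lower number from compound 1 to compound 3 (2.38 log units; beyond the scatter)), so these three compounds fall in the order methyl, difluoromethyl, chloro(difluoro)methyl. From the compounds shown here alone, whether trifluoromethyl or bromo(difluoro)methyl would continue this order remains open. Nothing shown gives a measured reason for the order.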